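Replacing the Hydroxypropyl Chain on the Triazole Nitrogen

The source may report more compounds than this note shows. Statements on the series, on what has been measured and on what is new or still open speak of the compounds shown alone.

Of the compounds shown here, three sharing one core have been measured in a functional assay on HT-29 cells (Homo sapiens) for inhibition, read by luminescence and CellTiter-Glo, with a stated time of 24 h; on this read-out higher numbers stand for an effect only at larger amounts of compound and lower numbers for an effect already at smaller amounts. Compound 1 `CN1C(=S)[C@@H](NC(=O)c2nc(Cc3ccccc3)n(C)n2)COc2ccccc21` gives 2.5 nM. Compound 2 `CN1C(=S)[C@@H](NC(=O)c2nc(Cc3ccccc3)n(CCCO)n2)COc2ccccc21` gives 209 nM, and compound 3 `CN1C(=S)[C@@H](NC(=O)c2nc(Cc3ccccc3)n(C3COC3)n2)COc2ccccc21` gives 916 nM. Compound 2 thus stands second highest of the three numbers; its nearest neighbour is compound 3, while compound 1 lies furthest from it, as the steps show: an 84-fold higher number from compound 1 to compound 2 (1.92 log units; beyond the scatter), a 370-fold higher number from compound 1 to compound 3 (2.56 log units; beyond the scatter) and a 4.4-fold higher number from compound 2 to compound 3 (0.64 log units; beyond the scatter).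

Compound 4 `CN1C(=S)[C@@H](NC(=O)c2nc(Cc3ccccc3)n(C3CCOCC3)n2)COc2ccccc21` is not yet measured. It differs from compound 2 at a single place: oxan-4-yl in place of 3-hydroxypropyl on an aromatic nitrogen.

Among the measured compounds shown here, the step bearing most directly on this change is the one from compound 2 to compound 3, where a saturated ring with one hetero atom replaced the 3-hydroxypropyl group and the number rose modestly. Oxan-4-yl is likewise a ring bearing one oxygen and no donor, so a modest rise in this assay is expected for compound 4, with an estimated step of a 2.9-fold higher number from compound 2 to compound 4 (0.46 log units; beyond the scatter). Compound 4 is therefore estimated at 600 nM, expected to fall between 150 nM and 3000 nM.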

Compound 4, half-maximal effective concentration: 2260 nM
Beside the measured number, compound 4's estimate is 3.8-fold (0.58 log units) below it; the measured number falls inside the stated range.
By their numbers in this assay, from the lowest: compound 1; then compound 2; then compound 3; then compound 4.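

In this assay, the oxan-4-yl group on the aromatic nitrogen gives a large step (an 11-fold higher number from compound 2 to compound 4 (1.03 log units; beyond the scatter)), so a ring bearing one oxygen at this position need not stay within the modest step seen with oxetan-3-yl. The two rings also differ from each other beyond the scatter (a 2.5-fold higher number from compound 3 to compound 4 (0.39 log units; beyond the scatter)), which shows that the number here depends on ring size and not only on the presence of a ring with one oxygen. Compound 4 lies furthest from the methyl compound (a 900-fold higher number from compound 1 to compound 4 (2.96 log units; beyond the scatter)), extending the range at this position, and nothing available explains the rise.

The compounds shown leave open how the number changes between methyl and these larger groups, since ethyl and 2-methoxyethyl do not appear among them. They also leave open whether a chain ending in an amine or a carboxylic acid would fall nearer compound 1 or compound 4.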